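Swapping the ester for an ether on the naphthoquinone side chain

The source may hold more compounds than are shown below. What is called first, only, known or untested is meant among the compounds shown, and "the series" means these compounds.

Measured so far:
compound 1, `CC(C)=CC[C@@H](OC(=O)c1ccoc1)C1=CC(=O)c2c(O)ccc(O)c2C1=O`: > 100000 nM
compound 2, `CC(C)=CC[C@@H](OC(=O)C1CCCCO1)C1=CC(=O)c2c(O)ccc(O)c2C1=O`: 24700 nM

Compound 1 gives only a limit of the assay, > 100000 nM, in a functional assay on DU-145 cells (Homo sapiens) for cytotoxicity, read by MTT assay; on this read-out higher numbers stand for weaker inhibition and lower numbers for stronger inhibition. Going by the values given here, compound 2 gives 24700 nM, the only finished number among the values shown, so it is the one fixed point of the series. The measured step of an at least 4.0-fold lower number from compound 1 to compound 2 (0.60 log units; beyond the scatter) arose from oxan-2-yl in place of furan-3-yl on a carbonyl carbon, and it rests on (the limit of > 100000 nM in this assay, at which 1 of the 2 values shown sits).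

Compound 3, `CCC(CO[C@H](CC=C(C)C)C1=CC(=O)c2c(O)ccc(O)c2C1=O)OC(C)=O`, differs from compound 2 by 2-acetoxybutyl in place of (oxan-2-yl)carbonyl on an oxygen on a saturated carbon. Among the compounds with values here, no measured step touches this kind of change; the only step recorded concerns a ring swap that stays within the same place. The expected step is therefore a 1.1-fold higher number from compound 2 to compound 3 (0.05 log units; within the scatter), not beyond the scatter in either direction. Compound 3 is expected to give about 28000 nM, within a range from 8000 nM to 90000 nM.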

Compound 3, half-maximal inhibitory concentration: 25400 nM
Compound 3: the middle estimate sits 1.1-fold (0.04 log units) above what was measured, within the range that was stated.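

At this oxygen on a saturated carbon, replacing (oxan-2-yl)carbonyl with 2-acetoxybutyl gives a 1.0-fold higher number from compound 2 to compound 3 (0.01 log units; within the scatter) in this assay. In this pair, then, a group with no ring and no carbonyl directly on that oxygen matches a ring-bearing group with the same count of heavy atoms, so neither feature is required for a value of this size. Measured against the furan-3-yl compound, the new group gives an at least 3.9-fold lower number from compound 1 to compound 3 (0.59 log units; beyond the scatter), but the value of compound 1 is a limit and not a finished number: the limit of > 100000 nM in this assay, at which 1 of the 3 values shown sits.

Going by these compounds, whether an amine, a carboxylic acid or a longer chain on this oxygen would move the value remains open. Also open, on these data alone, is whether compound 2 and compound 3 would still match in cells other than those of this assay.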